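From compound 2 to compound 4: one nitrogen group exchanged

The compounds below may be only part of what the source reports. "The series", "measured", "known", "first", "only" and "open" are said of these compounds alone.

Of the compounds shown here, three have been measured in a functional assay on HOS-TE85 cells (Homo sapiens) for inhibition, read by CCK-8 assay, with a stated time of 72 h; on this read-out lower numbers stand for stronger inhibition and higher numbers for weaker inhibition. Compound 1 `O=C(NCCCCn1cccn1)c1cccc(C2SCC(=O)N2c2cc(Br)ccn2)c1` gives 105 nM. Compound 3 `O=C(NCCCCn1cccn1)c1cccc(C2SCC(=O)N2c2cccnc2)c1` reads > 1000 nM, which is a limit of the assay and not a number. Compound 2 `CC(C)(C)c1conc1N1C(=O)CSC1c1cccc(C(=O)NCCCCc2ccccc2)c1` reads > 1000 nM, which is also a limit and not a number.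

Compound 4 `COc1cc(F)ccc1N1C(=O)CSC1c1cccc(C(=O)NCCCCc2ccccc2)c1` differs from compound 2 in one group: a group of 9 heavy atoms (7 carbon, 1 oxygen, 1 fluorine; one six-membered aromatic ring of carbon only) in place of a group of 9 heavy atoms (7 carbon, 1 nitrogen, 1 oxygen; one five-membered aromatic ring with 2 hetero atoms), on an amide-type nitrogen in a ring. The incoming group is 4-fluoro-2-methoxyphenyl. Within the data shown here, the only measured step at this kind of place is pyridin-3-yl in place of 4-bromopyridin-2-yl, which gave an at least 9.5-fold higher number from compound 1 to compound 3 (0.97 log units; beyond the scatter). That step lies beyond the scatter, so the group on this nitrogen can matter, at least in compound 1 and compound 3. Among the measured compounds shown here, both of those compounds also differ from compound 2 elsewhere in the molecule, and no measured compound carries the 4-fluoro-2-methoxyphenyl group. The step therefore suggests that a change is possible, but it gives only a loose guide to its size.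

A modest move towards a lower number is expected, and the estimated change is an at least 1.6-fold lower number from compound 2 to compound 4 (0.22 log units; that floor lies within the scatter). For compound 4 the expected value is 600 nM, with an estimated range of 120 nM to 3000 nM.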

Compound 4, half-maximal inhibitory concentration: 71.1 nM
The estimate for compound 4 lay 8.4-fold (0.93 log units) above the measured number; the whole stated range lies above it.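

In this assay, exchanging this one group gives an at least 14-fold lower number from compound 2 to compound 4 (1.14 log units; beyond the scatter). Among these compounds, until now, the only step at the amide-type nitrogen came from compound 1 and compound 3, which share a different amide chain; this step shows that the group on the nitrogen also matters with the amide chain shared by compound 2 and compound 4. It also shows that a ring of carbon only, 4-fluoro-2-methoxyphenyl, can stand on this nitrogen and give a clearly lower number, so a ring nitrogen in this group is not needed for that. The printed step is only a floor, and its full size stays unknown because compound 2 is known only as a limit: the limit of > 1000 nM in this assay, at which 2 of the 4 values shown sit.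

The compounds shown do not tell whether the fluorine, the methoxy group or the phenyl ring itself accounts for the change, which a plain phenyl ring or a phenyl ring carrying only one of the two groups could help to separate. They also leave open whether 4-fluoro-2-methoxyphenyl would give a similar change with the amide chain of compound 1.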